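The source may report more compounds than this note shows. Statements on the series, on what has been measured and on what is new or still open speak of the compounds shown alone.

Measured in a functional assay on HEK293 cells with Glucose-dependent insulinotropic receptor (Homo sapiens) as the target, read by cAMP accumulation, with a stated time of 60 min; a lower number here means a smaller maximal response, a higher number a larger maximal response:
compound 1 `CCCS(=O)(=O)N1CC=C(c2ccc3c(c2)CC(C2CCN(C(=O)OC(C)C)CC2)O3)CC1` gives 61%;
compound 2 `CCCS(=O)(=O)N1CC=C(c2ccc3c(c2)CC(C2CCN(S(=O)(=O)CCC)CC2)O3)CC1` gives 43%;
compound 3 `CCCc1cnc(N2CCC(C3Cc4c(ccc(C5=CCN(S(=O)(=O)CCC)CC5)c4F)O3)CC2)nc1` gives 123%.

Compound 3 stands highest of the three, beyond the scatter against both compound 1 and compound 2. Compound 4 `CCCc1cnc(N2CCC(C3Cc4c(F)c(C5=CCN(S(=O)(=O)CCC)CC5)cc(F)c4O3)CC2)nc1` differs from compound 3 by fluoro in place of hydrogen on an aromatic carbon. Among the compounds with values here, the only measured step, a number 18 percentage points lower from compound 1 to compound 2 (beyond the scatter), concerns an exchange on an amine nitrogen in a ring and does not bear on a fluoro entering an aromatic ring; no measured pair covers such a change. Within the data shown here, with no precedent to draw on, no movement beyond the scatter is expected in this assay, so the estimated change is a number 8 percentage points lower from compound 3 to compound 4 (within the scatter). Compound 4 is expected at 115%, with a range of 85% to 145%.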

Compound 4, largest response reached (Emax), in percent of the reference or control that the assay uses in the Glucose-dependent insulinotropic receptor assay: 119%
Estimate against measurement, compound 4: 4 percentage points below, and the stated range covers the measured number.
By their numbers in the Glucose-dependent insulinotropic receptor assay, from the lowest: compound 2; then compound 1; then compounds 4 and 3 (each within the scatter of the next).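

Fluoro in place of hydrogen on an aromatic carbon, para to a fluoro group, is the first change tested at this position, and in the Glucose-dependent insulinotropic receptor assay it gives a number 4 percentage points lower from compound 3 to compound 4 (within the scatter). In a physicochemical assay for solubility, at pH 6.5 (on this read-out higher numbers stand for higher solubility and lower numbers for lower solubility), compound 3 gives < 1 ug/mL, which is a limit of the assay. In the physicochemical assay compound 4 gives < 1 ug/mL, also a limit, so the step in solubility cannot be read: the limit of < 1 ug/mL in the physicochemical assay, at which 2 of the 2 values shown sit.

Open, on these data alone, is how a methoxy group or a chloro group at this position would read in the Glucose-dependent insulinotropic receptor assay. Also open, as far as these compounds go, is whether an amine there would give a readable number in the physicochemical assay.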